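From chloro to fluoro: expectation for compound 4

A few compounds are considered here, and "the series" means these few. Any claim that something is new, unique, unknown or untested is made for them only; others in the source may bear on it.

Compound 1 `CCC(C(=O)N1CCN(c2cccc(Cl)c2)CC1)N1C(=O)CCC1=O` is tested in a functional assay on the whole organism (strain Swiss) with Mus musculus as the target, in the maximal electroshock model, with a stated time of 0.5 h, at a dose of 100 mg/kg by the intraperitoneal route (a lower number here means a weaker effect, a higher number a stronger effect of the compound at the dose given), where compound 1 gives 50%. Among the three measured compounds this is the second highest number: compound 2 `CC(C(=O)N1CCN(c2cccc(Cl)c2)CC1)N1C(=O)CCC1=O` gives 75%, and compound 3 `CC(C(=O)N1CCN(c2ccc(F)cc2)CC1)N1C(=O)CCC1=O` gives 0%. The two measured steps are a number 25 percentage points higher from compound 1 to compound 2 (beyond the scatter), a change of hydrogen in place of methyl on a saturated chain carbon, and a number 75 percentage points lower from compound 2 to compound 3 (beyond the scatter), a change of 4-fluorophenyl in place of 3-chlorophenyl on an amine nitrogen in a ring.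

Compound 4 `CCC(C(=O)N1CCN(c2cccc(F)c2)CC1)N1C(=O)CCC1=O` differs from compound 1 by fluoro in place of chloro on an aromatic carbon. The step from compound 1 to compound 2 concerns the chain and does not bear on this change. Within the data shown here, the step from compound 2 to compound 3 swaps the chloro-bearing ring for a fluoro-bearing one, but also shifts the halogen to another position, so it bears on the change only in part; no measured pair isolates chloro against fluoro at the same place. On this partial evidence a drop in this assay is expected, smaller than the step from compound 2 to compound 3 and with wide uncertainty. For compound 4 the expected value is 25%, within 0% to 60%, which is a step of a number 25 percentage points lower from compound 1 to compound 4 (beyond the scatter).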

Compound 4, a percentage reported as activity, at one dose (the size of the read-out at that dose, not a potency): 0%
Compound 4: middle estimate off by 25 percentage points, on the high side; the measured number falls inside the stated range.
By their numbers in this assay, from the lowest: compounds 3 and 4 (each within the scatter of the next); then compound 1; then compound 2.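

In this assay, the change from 3-chlorophenyl to 3-fluorophenyl gives a number 50 percentage points lower from compound 1 to compound 4 (beyond the scatter), with the chain and the rest of the core of compound 1 unchanged. This isolates chloro against fluoro on this aromatic carbon, showing that the two halogens are not interchangeable here at the dose given. Among these compounds, until now, the only fluoro-bearing compound was compound 3, where halogen and position changed together, whereas this single exchange, with no shift of the halogen, is enough for a large step; nothing measured here accounts for the drop.

Still open, on these data alone, is how other groups on this aromatic carbon would read in this assay, such as bromo, trifluoromethyl, methoxy or plain hydrogen, and so whether chloro is a special case or one of several tolerated groups. Also open, as far as these compounds go, is whether the hydrogen in place of methyl on the chain, which raises the number on the 3-chlorophenyl series, would restore any effect when combined with 3-fluorophenyl.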